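Series notes: acylguanidines with a methylsulfonyl group

A few compounds are considered here, and "the series" means these few. Any claim that something is new, unique, unknown or untested is made for them only; others in the source may bear on it.

Measured compounds:
- compound 1, `Cc1c(C(=O)N=C(N)N)cc(S(C)(=O)=O)c(Cl)c1Cl`, in a functional assay for inhibition of sodium/hydrogen exchanger (Oryctolagus cuniculus) (a lower number here means a stronger inhibitor, a higher number a weaker inhibitor), gives 29 nM
- compound 2, `Cc1c(C(=O)N=C(N)N)cc(S(C)(=O)=O)c(C)c1C`, in this assay gives 55 nM
- compound 3, `Cc1cc(-c2ccco2)c(S(C)(=O)=O)cc1C(=O)N=C(N)N`, in this assay gives 16 nM

Compound 3 shows the lowest number of the three, but its gap to compound 1 lies within the scatter, so no order between the two can be read; only the higher number of compound 2 stands beyond the scatter.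

The next compound is compound 4, `Cc1cc(OC2CCCC2)c(S(C)(=O)=O)cc1C(=O)N=C(N)N`. It differs from compound 3 by cyclopentyloxy in place of furan-2-yl on an aromatic carbon. Among the compounds with values here, no step between measured compounds covers such a change, so nothing measured points a direction. A small shift in this assay, not beyond the scatter, is expected. The step of a 1.6-fold higher number from compound 3 to compound 4 (0.19 log units; within the scatter) is expected to stay within the scatter. Compound 4 is expected to give about 25 nM, in a range from 8 nM to 80 nM.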

Compound 4, half-maximal inhibitory concentration: 27 nM
Compound 4: the middle estimate sits 1.1-fold (0.03 log units) below what was measured; the measured number falls inside the stated range.
By their numbers in this assay, from the lowest: compounds 3, 4, 1 and 2 (each within the scatter of the next, the first and the last beyond it).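

Cyclopentyloxy in place of furan-2-yl, on the aromatic carbon ortho to the methylsulfonyl group, gives in this assay a 1.7-fold higher number from compound 3 to compound 4 (0.23 log units; within the scatter). This position therefore accepts either a five-membered aromatic ring or cyclopentyloxy, with no difference that can be read between them. Nothing at hand bears on why the two groups read alike.

As far as these compounds go, whether an amine, a carboxylic acid or a longer alkoxy chain at this position would stay level with these two remains open. The compounds shown hold no step at this place beyond the scatter.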